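Weak cytotoxicity shifts with halogens on one aryl ring

A few compounds are considered here, and "the series" means these few. Any claim that something is new, unique, unknown or untested is made for them only; others in the source may bear on it.

Compound 3 `Cn1ccc2c(Oc3ccc(NC(=O)c4nn(-c5ccc(Br)cc5F)ccc4=O)cc3F)ccnc21` is the only one of the three measured compounds that gives a number: in a functional assay on A549 cells (Homo sapiens) for cytotoxicity, read by MTT assay, with a stated time of 72 h (a higher number here means a weaker inhibitor, a lower number a stronger inhibitor), compound 3 gives 26800 nM. Compound 1 `Cn1ccc2c(Oc3ccc(NC(=O)c4nn(-c5ccc(Cl)cc5)ccc4=O)cc3F)ccnc21` reaches only a limit of this assay, > 60000 nM. Compound 2 `Cn1ccc2c(Oc3ccc(NC(=O)c4nn(-c5ccc(Br)cc5)ccc4=O)cc3F)ccnc21` likewise stops at a limit, > 60000 nM. Most of the values sit at the limit of > 60000 nM in this assay, at which 2 of the 3 values shown sit. Compound 4 `Cn1ccc2c(Oc3ccc(NC(=O)c4nn(-c5ccc(Cl)c(C(F)(F)F)c5)ccc4=O)cc3F)ccnc21` alters the ring on the aromatic nitrogen: 4-chloro-3-(trifluoromethyl)phenyl in place of 4-bromo-2-fluorophenyl on an aromatic nitrogen. Going by the values given here, two steps touch this ring, an at least 2.2-fold lower number from compound 1 to compound 3 (0.35 log units; beyond the scatter) and an at least 2.2-fold lower number from compound 2 to compound 3 (0.35 log units; beyond the scatter), while a step that the two limits leave unreadable from compound 1 to compound 2. Since compound 4 lacks the fluoro whose arrival gave an at least 2.2-fold lower number from compound 2 to compound 3 (0.35 log units; beyond the scatter), a somewhat higher number is expected, a 1.7-fold higher number from compound 3 to compound 4 (0.23 log units; within the scatter). Compound 4 is therefore estimated at 45000 nM, within a range from 18000 nM to 110000 nM.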

Compound 4, half-maximal inhibitory concentration: 17700 nM
For compound 4 the middle estimate is 2.5-fold (0.41 log units) above the measured one; measured number outside the range, below it.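

On the ring on the aromatic nitrogen, trifluoromethyl in place of hydrogen gives an at least 3.3-fold lower number from compound 1 to compound 4 (0.53 log units; beyond the scatter), and the exchange of the whole ring gives an at least 3.3-fold lower number from compound 2 to compound 4 (0.53 log units; beyond the scatter). A readable number in this assay therefore does not depend on the fluoro of compound 3, and the two differently substituted rings sit level, with a 1.5-fold lower number from compound 3 to compound 4 (0.18 log units; within the scatter). Both larger steps are minimum sizes because their starting compounds stop at a limit: the limit of > 60000 nM in this assay, at which 2 of the 4 values shown sit.

As far as these compounds go, what an amine or a carboxylic acid on this ring would do stays open, as does whether trifluoromethyl gives the same step without the chloro.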